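The compounds below may be only part of what the source reports. "The series", "measured", "known", "first", "only" and "open" are said of these compounds alone.

Compound 1, `Cc1cc(NC(=O)Nc2ncccc2C)c2ccccc2n1`, in an ADME assay on Raji cells (Homo sapiens) for cytotoxicity, with a stated time of 72 h; a higher number here means that more compound is needed for the effect, a lower number that less compound is needed: > 25000 nM, a limit of the assay rather than a number.
Compound 2, `Cc1cc(NC(=O)Nc2ccc(N)cc2)c2ccccc2n1`: > 25000 nM, again a limit.
Compound 3, `Cc1cc(NC(=O)Nc2ccccc2F)c2ccccc2n1`: > 25000 nM, also a limit.

Compound 3 thus stands at the limit of the assay, and so do the other two measured compounds; none of the three gave a number. Compound 4, `Cc1cc(NC(=O)Nc2ccc(F)cc2)c2ccccc2n1`, is not yet measured. It differs from compound 3 only in the group on the amide-type nitrogen: 4-fluorophenyl in place of 2-fluorophenyl on an amide-type nitrogen.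

The measured steps that touch this position are a step that the two limits leave unreadable from compound 1 to compound 3, a step that the two limits leave unreadable from compound 2 to compound 3 and a step that the two limits leave unreadable from compound 1 to compound 2. None of them can be read, because every value sits at the limit of > 25000 nM in this assay, at which 3 of the 3 values shown sit. So there is no measured step of known size to lean on, and no direction can be predicted beyond the scatter. Since all three measured compounds share the same limit, the change from 2-fluorophenyl to 4-fluorophenyl is expected to leave compound 4 at the limit as well. Compound 4 is therefore estimated at 30000 nM, within 10000 nM to 100000 nM, which means an expected step that the limit leaves unreadable from compound 3 to compound 4.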

Compound 4, half-maximal effective concentration: > 25000 nM
Compound 4 was reported as a limit; the forecaster's own chance of this, stated with the estimate: 85%; the middle value is on the limit's open side.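

Compound 4 also gave a limit rather than a number, so none of its steps from compound 1, compound 2 or compound 3 can be read, and all four compounds share one reading: the limit of > 25000 nM in this assay, at which 4 of the 4 values shown sit.
The compounds shown leave open whether any group on the amide-type nitrogen can give a real number in this assay rather than a limit.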